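Dropping the Methyl From the Amide Aryl Group of Compound 1

The source may hold more compounds than are shown below. What is called first, only, known or untested is meant among the compounds shown, and "the series" means these compounds.

Measured compounds:
compound 1, `COc1ccc2c(=O)c(/C=C/C(=O)Nc3ccc(C)cc3)coc2c1`, gives 24100 nM in a functional assay on HeLa cells (Homo sapiens) for inhibition, read by MTT assay, with a stated time of 48 h; on this read-out lower numbers stand for stronger inhibition and higher numbers for weaker inhibition;
compound 2, `COc1ccc2c(=O)c(/C=C/C(=O)NCc3cccc(F)c3)coc2c1`, gives 17600 nM;
compound 3, `COc1ccc2c(=O)c(/C=C/C(=O)Nc3cc(C)ccc3C)coc2c1`, gives 58400 nM.

Among these three numbers, compound 1 stands second highest. The gap to compound 2 is small, a 1.4-fold lower number from compound 1 to compound 2 (0.14 log units; within the scatter), so the two cannot be ordered. The gap to compound 3 is larger, a 2.4-fold higher number from compound 1 to compound 3 (0.38 log units; beyond the scatter), a modest weakening when a second methyl is added and the first moves.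

Compound 4, `COc1ccc2c(=O)c(/C=C/C(=O)Nc3ccccc3)coc2c1`, differs from compound 1 in one place: hydrogen in place of methyl on an aromatic carbon.

Going by the values given here, no measured step removes a group from this ring; the two measured steps add methyls or swap the whole group. Compound 3 shows that more methyl on the ring weakens inhibition modestly, while compound 2 shows that a quite different group leaves the number within the scatter. Removing the single methyl is therefore expected to change little, giving an expected step of a 1.2-fold lower number from compound 1 to compound 4 (0.08 log units; within the scatter). Compound 4 is estimated at 20000 nM, with a range from 8000 nM to 50000 nM.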

Compound 4, half-maximal inhibitory concentration: > 100000 nM
Compound 4 gave a limit, no number; the forecaster's own chance of this, stated with the estimate: 5%; middle value at least 5.0-fold (0.69 log units) from the limit.
By their numbers in this assay, from the lowest: compounds 2 and 1 (each within the scatter of the next); then compound 3. At a limit, above all of these: compound 4.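

In this assay, going by these compounds alone, compound 4 gives a limit and not a number: the limit of > 100000 nM in this assay, at which 1 of the 4 values shown sits. The methyl para to a large group therefore matters more than the earlier compounds suggested, since removing it gives an at least 4.1-fold higher number from compound 1 to compound 4 (0.61 log units; beyond the scatter), while compound 3 had only tied more methyl on this ring to a weaker number; methyl count alone does not order these compounds, as compound 4, with none, and compound 3, with two, both stand above compound 1. The unsubstituted phenyl also stands apart from the other amide groups, with an at least 5.6-fold higher number from compound 2 to compound 4 (0.75 log units; beyond the scatter) and an at least 1.7-fold higher number from compound 3 to compound 4 (0.23 log units; that floor lies within the scatter).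

Going by these compounds, whether the methyl itself is needed, or whether another group at this place, such as a chlorine or an amine, would serve as well, stays open. The compounds shown also do not tell why inhibition falls away when the methyl is gone.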